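Iodo in place of chloro on a well-tolerated core

The source may hold more compounds than are shown below. What is called first, only, known or untested is meant among the compounds shown, and "the series" means these compounds.

In an ADME assay on Huh-7 cells (Homo sapiens) for cytotoxicity, read by scintillation counting, with a stated time of 2 days (a higher number here means that more compound is tolerated, a lower number that less compound is tolerated), compound 2 `Cc1cn([C@H]2C[C@H](Cl)[C@@H](CO)O2)c(=O)[nH]c1=O` gives > 100 ug/mL as a limit and not a number. Compound 1 `Cc1cn([C@H]2C[C@H](Br)[C@@H](CO)O2)c(=O)[nH]c1=O` likewise gives > 100 ug/mL as a limit. Within the data shown here, the only measured step is a step that the two limits leave unreadable from compound 1 to compound 2 and so offers no size to carry forward. Compound 3 `Cc1cn([C@H]2C[C@H](I)[C@@H](CO)O2)c(=O)[nH]c1=O` has iodo in place of chloro on a saturated ring carbon. No change beyond the usual scatter is therefore expected in this assay in either direction. The estimated step is a number no higher from compound 2 to compound 3 (the limit leaves the size open) on this reasoning. For compound 3 the estimated value is 100 ug/mL with an expected range from 40 ug/mL to 200 ug/mL in this measurement.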

Compound 3, half-maximal cytotoxic concentration: > 100 ug/mL
Compound 3: only a limit was reported (the forecaster's own chance of this, stated with the estimate: 75%); the middle value lies on the limit itself.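

Among these compounds, compound 1, compound 2 and compound 3 each give a limit and not a number, so no step among them can be read: the limit of > 100 ug/mL in this assay, at which 3 of the 3 values shown sit. As far as these compounds go, the concentration at which each compound harms the cells stays open, as does whether bromo, chloro and iodo differ at all.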